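The source may hold more compounds than are shown below. What is called first, only, known or untested is meant among the compounds shown, and "the series" means these compounds.

Working notes on the series. The three measured compounds share one core and differ in the aryl groups at its two ends: compound 1 `COc1ccc(-c2nc(C)c(C(=O)CSc3nc(-c4cccc(OC)c4)c(C#N)c(=O)[nH]3)s2)cc1`, compound 2 `Cc1nc(-c2ccc(Cl)cc2)sc1C(=O)CSc1nc(-c2cccc(Cl)c2)c(C#N)c(=O)[nH]1` and compound 3 `COc1ccc(-c2nc(C)c(C(=O)CSc3nc(-c4ccc(Cl)cc4)c(C#N)c(=O)[nH]3)s2)cc1`. Among the compounds with values here, in a functional assay on U-87MG ATCC cells for antiproliferative activity against U-87 MG (Homo sapiens), read by MTT assay, with a stated time of 48 h (on this read-out higher numbers stand for weaker inhibition and lower numbers for stronger inhibition), compound 1 gives 15300 nM, compound 2 gives 40100 nM and compound 3 gives 45900 nM, the highest of the three numbers; the gap from compound 3 to compound 2 is within the scatter, while the only single-point step in the set, a 3.0-fold higher number from compound 1 to compound 3 (0.48 log units; beyond the scatter), is a modest one beyond it.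

Compound 4 `COc1ccc(-c2nc(C)c(C(=O)CSc3nc(-c4cccc(Cl)c4)c(C#N)c(=O)[nH]3)s2)cc1` is the next compound, differing from compound 3 only in this way: 3-chlorophenyl in place of 4-chlorophenyl on an aromatic carbon. Within the data shown here, no measured step in this assay isolates that change, so the move from one chlorophenyl isomer to the other has no direct precedent here. What can be said is that compound 2, which also carries a 3-chlorophenyl, sits within the scatter of compound 3 in this assay, though compound 2 differs from compound 4 in a second place as well. The expectation for compound 4 is therefore a step of a 1.2-fold lower number from compound 3 to compound 4 (0.08 log units; within the scatter), that is, no change beyond the scatter. Compound 4 is estimated at 38000 nM, with a plausible range from 15000 nM to 90000 nM.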

Compound 4, half-maximal inhibitory concentration: 78900 nM
For compound 4 the middle estimate is 2.1-fold (0.32 log units) below the measured one, within the range that was stated.
By their numbers in this assay, from the lowest: compound 1; then compounds 2, 3 and 4 (each within the scatter of the next).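

In this assay the shift from 4-chlorophenyl to 3-chlorophenyl at this position gives a 1.7-fold higher number from compound 3 to compound 4 (0.24 log units; within the scatter) and so does not separate the two chlorophenyl isomers, while methoxy in place of chloro on the aryl group at the other end of the core gives a 2.0-fold higher number from compound 2 to compound 4 (0.29 log units; within the scatter) and is equally unresolved. The change that does register is chloro in place of methoxy on the 3-substituted phenyl, with a 5.2-fold higher number from compound 1 to compound 4 (0.71 log units; beyond the scatter) joining a 3.0-fold higher number from compound 1 to compound 3 (0.48 log units; beyond the scatter), so that among the compounds with a methoxy group on the other aryl group, both chlorophenyl isomers stand beyond the scatter from the 3-methoxyphenyl of compound 1. Nothing at hand explains these steps.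

Going by these compounds, it remains open whether the lower number of compound 1 belongs to the methoxy group itself or to any group other than chloro at this position, which a hydroxy group, an ethoxy chain or an amine in its place would test. On these data alone, whether a 3-methoxyphenyl keeps that standing with a 4-chlorophenyl at the other end of the core is also open.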